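A few compounds are considered here, and "the series" means these few. Any claim that something is new, unique, unknown or untested is made for them only; others in the source may bear on it.

In a functional assay on PC-3 cells (Homo sapiens) for antiproliferative activity, read by MTT assay, with a stated time of 72 h (on this read-out higher numbers stand for weaker inhibition and lower numbers for stronger inhibition), compound 1 `COc1cc(/C=C/C(O)=C/C(=O)/C=C/c2ccc(OC(=O)C(C)(CO)CO)c(OC)c2)ccc1O` gives 17400 nM, compound 2 `COc1ccc(/C=C/C(=O)/C=C(O)/C=C/c2ccc(OC)c(OC(=O)C(C)(CO)CO)c2)cc1OC(=O)C(C)(CO)CO` gives 4740 nM, and compound 3 `COc1ccc(/C=C/C(O)=C/C(=O)/C=C/c2ccc(OC)c(OC(=O)C(C)(CO)CO)c2)cc1O` gives 2320 nM, the lowest of the three numbers. Compound 4 `CCC(CO)(CO)C(=O)Oc1cc(/C=C/C(=O)/C=C(O)/C=C/c2ccc(OC)c(O)c2)ccc1OC` is still unmeasured. It departs from compound 3 by methyl in place of hydrogen on a saturated chain carbon, two bonds along the chain from a carbonyl carbon, with methyl in place of hydrogen on a saturated chain carbon, two bonds along the chain from a carbonyl carbon, so that methyl becomes ethyl. Within the data shown here, the only measured step, a 2.0-fold lower number from compound 2 to compound 3 (0.31 log units; beyond the scatter), is modest and removes a whole (1,1-bis(hydroxymethyl)ethyl)carbonyl, so it bears only loosely on this change. In this assay no shift beyond the scatter is therefore expected, and the estimated step is a 1.1-fold higher number from compound 3 to compound 4 (0.03 log units; within the scatter). For compound 4 the expected value is 2500 nM, with an estimated range of 1100 nM to 5500 nM.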

Compound 4, half-maximal inhibitory concentration: 7030 nM
Compound 4: the middle estimate sits 2.8-fold (0.45 log units) below what was measured; measured number outside the range, above it.
By their numbers in this assay, from the lowest: compound 3; then compounds 2 and 4 (each within the scatter of the next); then compound 1.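

In this assay the change from methyl to ethyl gives a 3.0-fold higher number from compound 3 to compound 4 (0.48 log units; beyond the scatter) and so shows that this saturated chain carbon, two bonds along the chain from a carbonyl carbon, responds to one added carbon. The earlier step had removed the whole (1,1-bis(hydroxymethyl)ethyl)carbonyl and said nothing about a change within it. No measured evidence here accounts for this step. Going by these compounds, whether a longer chain such as propyl would raise the number further remains open. So does the outcome with an amine in place of the ethyl.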